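The source may hold more compounds than are shown below. What is called first, only, known or untested is meant among the compounds shown, and "the series" means these compounds.

In a physicochemical assay for solubility, read by HPLC, in phosphate buffer, measured as kinetic solubility, at pH 7.4 (a lower number here means a less soluble compound, a higher number a more soluble compound), compound 2 (`CCC(=O)c1cc(-c2ccc(S(N)(=O)=O)cc2)nn1-c1ccc(Cl)cc1`) gives 49600 nM, within the scatter of compound 1 (`CN(C(=O)c1cc(-c2ccc(S(N)(=O)=O)cc2)n(-c2ccc(Cl)cc2)n1)C1CC1`) at 99600 nM. Compound 3 (`CCC(=O)c1cc(-c2ccc(S(N)(=O)=O)cc2)nn1-c1cccc(Cl)c1`) lies far lower at 700 nM. Compound 4 (`CN(C)C(=O)c1cc(-c2ccc(S(N)(=O)=O)cc2)nn1-c1ccc(Cl)cc1`) differs from compound 2 by a single change: dimethylamino in place of ethyl on a carbonyl carbon. Among the compounds with values here, no measured step makes this swap. Within the data shown here, the only measured step, a 71-fold lower number from compound 2 to compound 3 (1.85 log units; beyond the scatter), puts 3-chlorophenyl in place of 4-chlorophenyl, so it bears only indirectly, though it shows that one change can move this number a long way. No shift beyond the scatter is therefore expected, and the estimated step is a 1.0-fold higher number from compound 2 to compound 4 (0.00 log units; within the scatter). For compound 4 the estimated value is 50000 nM, with an expected range of 12000 nM to 150000 nM.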

Compound 4, solubility: 5200 nM
For compound 4 the middle estimate is 9.6-fold (0.98 log units) above the measured one; the whole stated range lies above it.
By their numbers in this assay, from the lowest: compound 3; then compound 4; then compounds 2 and 1 (each within the scatter of the next).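

In this assay, within the data shown here, the only step read before concerned the chlorophenyl group, and now the group on a carbonyl carbon also proves able to move the number, with a 9.5-fold lower number from compound 2 to compound 4 (0.98 log units; beyond the scatter) for dimethylamino in place of ethyl. Both groups count no ring, no net charge and no hydrogen-bond donors or acceptors, so those counts do not separate them, yet the step lies beyond the scatter. No measurement at hand gives a reason for this step.

From the compounds shown here alone, whether methylamino or a longer chain on that carbonyl carbon would stay closer to compound 2 or to compound 4 remains open. So does whether dimethylamino in place of ethyl gives a similar step when 3-chlorophenyl replaces 4-chlorophenyl.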